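The source may report more compounds than this note shows. Statements on the series, on what has been measured and on what is new or still open speak of the compounds shown alone.

Compound 1 `O=C(N/N=C/c1ccccc1)c1cccnc1Nc1cccc(C(F)(F)F)c1` is the starting point of this small series. In a functional assay on the whole organism (strain Wistar) for inhibition, with Rattus norvegicus as the target, read by paw edema, with a stated time of 4 h, at a dose of 10 mg/kg by the intraperitoneal route (on this read-out lower numbers stand for less inhibition and higher numbers for more inhibition at the one dose given (going by the name of the read-out)), compound 1 gives 31%. Compound 2 `O=C(N/N=C/c1cccc(Cl)c1)c1cccnc1Nc1cccc(C(F)(F)F)c1` carries chloro in place of hydrogen on an aromatic carbon, and in this assay compound 2 gives 40.4%; the step of a number 9.4 percentage points higher from compound 1 to compound 2 (within the scatter) is a small one. Compound 3 `CNc1ncccc1C(=O)N/N=C/c1ccccc1` belongs to a different core; how the two cores differ is not broken down here. In this assay compound 3 gives 14.8%, the lowest of the three numbers, with compound 1 the nearest and compound 2 the furthest of the measured compounds. Compound 4 `CNc1ncccc1C(=O)N/N=C/c1ccc(Cl)cc1` is not yet measured. It differs from compound 3 by chloro in place of hydrogen on an aromatic carbon. Within the data shown here, this is the same kind of change as the one from compound 1 to compound 2, but the place is not the same: there the chloro sits meta to a large group, here it sits para to a large group. Among the measured compounds shown here, on the core of compound 3 the step of a number 9.2 percentage points higher from compound 3 to compound 4 (within the scatter) is expected to be of a similar size to a number 9.4 percentage points higher from compound 1 to compound 2 (within the scatter), since that is the only comparable step measured. Compound 4 is therefore estimated to give 24% in this assay, expected to lie between 10% and 38%.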

Compound 4, a percentage reported as inhibition, in the whole organism at one dose (the size of the read-out at that dose, not a potency): 18.2%
Compound 4: the middle estimate sits 5.8 percentage points above what was measured; the measured number falls inside the stated range.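

In this assay the new step is a number 3.4 percentage points higher from compound 3 to compound 4 (within the scatter), and set beside the earlier step it does not differ from it: the same change on two cores in this assay, a number 9.4 percentage points higher (within the scatter) from compound 1 to compound 2 and a number 3.4 percentage points higher (within the scatter) from compound 3 to compound 4, 6 percentage points apart, within the scatter of two such steps. On these two cores, then, the chloro in place of hydrogen gives no sign of behaving differently from one core to the other. This does not show that the change carries over as a real gain, as two steps that each lie within the scatter cannot separate a small shared rise from no rise at all, and core and place also remain tied together, with the chloro para to a large group in compound 4 but not in compound 2.

The compounds shown leave open how the chloro would compare if it stood in the same place on both cores. They also leave open whether another group in that place, such as an amine or a carboxylic acid, would give a step beyond the scatter on either core.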